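Chloro for bromo in a series resting at the limit

The compounds below may be only part of what the source reports. "The series", "measured", "known", "first", "only" and "open" are said of these compounds alone.

Measured so far in an ADME assay on L02 cells (Homo sapiens) for cytotoxicity, read by MTT assay, with a stated time of 48 h; a higher number here means a weaker inhibitor, a lower number a stronger inhibitor:
compound 1 (`O=c1ccoc2cc(OCc3cn(Cc4cccc(Br)c4)nn3)ccc12`) gives > 300000 nM
compound 2 (`CC(C)(C)c1ccc(Cn2cc(COc3ccc4c(=O)ccoc4c3)nn2)cc1`) gives > 300000 nM
compound 3 (`C#CCOc1ccc2c(=O)ccoc2c1`) gives > 300000 nM

Each of these three results is a limit of the assay and not a number. Compound 1 returns > 300000 nM, which is a limit. Compound 2 likewise stops at a limit, > 300000 nM. Compound 3, the smallest of the three, also gives only a limit, > 300000 nM. For the measured compounds named here, compound 1 therefore stands exactly where the other two stand, as the limit of > 300000 nM in this assay, at which 3 of the 3 values shown sit, sums up, and no step between measured compounds can be read from these data.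

The compound not yet measured is compound 4 (`O=c1ccoc2cc(OCc3cn(Cc4cccc(Cl)c4)nn3)ccc12`). It differs from compound 1 by chloro in place of bromo on an aromatic carbon. Going by the values given here, no measured step exists to calibrate this change. Because compound 1 sits at > 300000 nM and nothing in this set points away from the limit, the step from compound 1 to compound 4 is expected to be none beyond the scatter, in either direction, so that a number no higher from compound 1 to compound 4 (the limit leaves the size open) is the estimated step. Compound 4 is accordingly expected to give about 300000 nM in this assay, with an estimated range from 150000 nM to 600000 nM, and most probably the assay will again report only a limit for compound 4.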

Compound 4, half-maximal inhibitory concentration: > 300000 nM
Compound 4 ended at the assay's limit; the forecaster's own chance of this, stated with the estimate: 85%; the middle value lies on the limit itself.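

For the compounds shown here, compound 4, like compound 1, gives only a limit in this assay, so no step for chloro in place of bromo can be read between compound 1 and compound 4. All results rest on one value: the limit of > 300000 nM in this assay, at which 4 of the 4 values shown sit.

The compounds shown leave open how far each lies beyond that limit, and whether chloro and bromo differ at all.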